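Bromo on the sulfonyl phenyl of compound 3

A few compounds are considered here, and "the series" means these few. Any claim that something is new, unique, unknown or untested is made for them only; others in the source may bear on it.

Values in a functional assay on SMMC-7721 cells (Homo sapiens) for cytotoxicity, read by MTT assay, with a stated time of 24 h (on this read-out higher numbers stand for weaker inhibition and lower numbers for stronger inhibition), stand as follows:
- compound 1 `COc1ccc(/C=C2\CN(C)C/C(=C\c3ccncc3)C2=O)c(OC)c1OC` gives 9080 nM here
- compound 2 `O=C1/C(=C/c2cccnc2)CN(S(=O)(=O)c2ccccc2)C/C1=C\c1ccccc1F` gives 19100 nM here
- compound 3 `O=C1/C(=C/c2ccncc2)CN(S(=O)(=O)c2ccccc2)C/C1=C\c1ccccc1F` gives 17500 nM here

Compound 3 lies within the scatter of both compound 1 and compound 2. Compound 4 `O=C1/C(=C/c2ccncc2)CN(S(=O)(=O)c2ccc(Br)cc2)C/C1=C\c1ccccc1F` carries bromo in place of hydrogen on an aromatic carbon as its change, bromo in place of hydrogen on an aromatic carbon, turning phenylsulfonyl into (4-bromophenyl)sulfonyl. Going by the values given here, the one measured step of a 1.1-fold lower number from compound 2 to compound 3 (0.04 log units; within the scatter) concerns pyridin-4-yl in place of pyridin-3-yl, and no measured step covers this bromo change. The expected outcome in this assay is a 1.3-fold lower number from compound 3 to compound 4 (0.10 log units; within the scatter) and nothing beyond the scatter in either direction. Compound 4 is estimated at 14000 nM with an expected range from 6000 nM to 30000 nM as the working figure.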

Compound 4, half-maximal inhibitory concentration: 12600 nM
For compound 4 the middle estimate is 1.1-fold (0.05 log units) above the measured one; the range from low to high includes it.
By their numbers in this assay, from the lowest: compounds 1, 4, 3 and 2 (each within the scatter of the next, the first and the last beyond it).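

The earlier compounds shown here showed no change on the sulfonyl phenyl. In this assay, putting bromo in place of hydrogen on its aromatic carbon, para to a large group, gives a 1.4-fold lower number from compound 3 to compound 4 (0.14 log units; within the scatter). This position therefore accepts bromo with no shift beyond the scatter, and no measurement bearing on the reason is available. Open, from the compounds shown here alone, is whether an amine or a carboxylic acid on this same aromatic carbon would leave the number within the scatter of compound 3 or move it beyond.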